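This account rests on a few compounds, and the source may have more. Where it says the series, first, only, none or still open, it means among the compounds named here.

In an ADME assay on BE(2)-C cells (Homo sapiens) for cytotoxicity, read by MTT assay, with a stated time of 20 h (on this read-out lower numbers stand for higher toxicity in this test and higher numbers for lower toxicity in this test), three compounds have been read. Compound 1 (`CC(NC(=O)C1CCN(C(=O)c2cc3ccccc3n2Cc2ccc(Cl)cc2)CC1)c1ccncc1`) gives 90100 nM on this scale, and compound 2 (`C[C@@H](NC(=O)C1CCN(C(=O)c2cc3ccccc3n2Cc2ccc(Cl)cc2)CC1)c1ccncc1`) gives 92300 nM there. Between them stands (the fact that one of compounds 1 and 2 is drawn with a defined configuration and the other without, at the place where they differ), and the step reads a 1.0-fold higher number from compound 1 to compound 2 (0.01 log units; within the scatter) here. Compound 3 (`CN1CCC(CNC(=O)C2CCN(C(=O)c3cc4ccccc4n3Cc3ccc(Cl)cc3)CC2)CC1`) stands only at a limit, > 50000 nM, and not at a number. On these data alone, its relation to the other two stays open: a step that the limit leaves unreadable from compound 1 to compound 3, and likewise a step that the limit leaves unreadable from compound 2 to compound 3 for the second comparison.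

Compound 4 (`Cn1ccc(CNC(=O)C2CCN(C(=O)c3cc4ccccc4n3Cc3ccc(Cl)cc3)CC2)n1`) has not yet been measured. It carries 1-methyl-1H-pyrazol-3-yl in place of 1-methylpiperidin-4-yl on a saturated chain carbon bound to an amide-type nitrogen. No measured step sizes this exchange. For the measured compounds named here, the one readable step, a 1.0-fold higher number from compound 1 to compound 2 (0.01 log units; within the scatter), concerns a stereocentre, and the two steps that touch this substituent have no readable size. Going by the values given here, the expectation therefore rests on the level of the series, with compound 1 at 90100 nM and compound 2 at 92300 nM as its only numbers. In this assay the expected step is a step that the limit leaves unreadable from compound 3 to compound 4, with no direction favoured and nothing foreseen beyond the scatter. Compound 4 is estimated at 75000 nM, with an expected range from 35000 nM to 160000 nM for its reading.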

Compound 4, half-maximal cytotoxic concentration: > 100000 nM
Compound 4: a limit, no number; the forecaster's own chance of this, stated with the estimate: 40%; middle value at least 1.3-fold (0.12 log units) away from the limit.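

In this assay compound 4, with 1-methyl-1H-pyrazol-3-yl in place of 1-methylpiperidin-4-yl on a saturated chain carbon bound to an amide-type nitrogen, gives > 100000 nM, which is a limit and not a number. Against the two compounds that carry 1-(pyridin-4-yl)ethyl on the amide-type nitrogen, the result gives only floors, an at least 1.0-fold higher number from compound 2 to compound 4 (0.03 log units; that floor lies within the scatter) and an at least 1.1-fold higher number from compound 1 to compound 4 (0.04 log units; that floor lies within the scatter), so no change beyond the scatter is established, though compound 4 adds a five-membered aromatic ring at this place without bringing a cytotoxic concentration into the readable range. The steps from compound 1 and compound 2 to compound 3 and the step from compound 3 to compound 4 cannot be read, so the exchange of the two rings has no size, and the reading for compound 4 stays a limit: the limit of > 100000 nM in this assay, at which 1 of the 4 values shown sits.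

The compounds shown leave open whether 1-methylpiperidin-4-yl and 1-methyl-1H-pyrazol-3-yl differ at all in this test. They also leave open how a primary amine or a carboxylic acid would read on a saturated chain carbon bound to an amide-type nitrogen.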